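The source may report more compounds than this note shows. Statements on the series, on what has been measured and on what is new or still open speak of the compounds shown alone.

Working notes on the series. Compound 1 `COc1cc(C(c2ccc(O)c(OC)c2)[C@H](C)[C@@H](C)CF)ccc1O` is the starting point; in a functional assay on HL-60 cells (Homo sapiens) for cytotoxicity, read by WST assay, with a stated time of 48 h (on this read-out lower numbers stand for stronger inhibition and higher numbers for weaker inhibition), compound 1 gives 45000 nM, the lowest of three numbers, though within the scatter of both neighbours. Compound 2 `COc1ccc(C(c2ccc(OC)c(OC)c2)[C@H](C)[C@@H](C)CO)cc1OC` gives 47000 nM in this assay, and compound 3 `COC[C@H](C)[C@@H](C)C(c1ccc(O)c(OC)c1)c1ccc(O)c(OC)c1` gives 68000 nM. The step of a 1.5-fold higher number from compound 1 to compound 3 (0.18 log units; within the scatter) shows a change at the same chain carbon leaving the read-out essentially unmoved. Compound 4 `COc1cc(C(c2ccc(O)c(OC)c2)[C@H](C)C(C)C)ccc1O` is not yet measured; it differs from compound 1 by hydrogen in place of fluoro on a saturated chain carbon, four bonds along the chain from two aromatic carbons. Among the measured compounds shown here, only the step to compound 3 bears on this change, and it stayed within the scatter, so no step beyond the scatter is expected in this assay. For compound 4 the expected result is 50000 nM, range 20000 nM to 125000 nM, an expected step of a 1.1-fold higher number from compound 1 to compound 4 (0.05 log units; within the scatter).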

Compound 4, half-maximal inhibitory concentration: 17000 nM
Beside the measured number, compound 4's estimate is 2.9-fold (0.47 log units) above it; the whole stated range lies above it.
By their numbers in this assay, from the lowest: compound 4; then compounds 1, 2 and 3 (each within the scatter of the next).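

In this assay, a change at this chain carbon now moves the number beyond the scatter: a 2.6-fold lower number from compound 1 to compound 4 (0.42 log units; beyond the scatter) with hydrogen in place of fluoro, and a 4.0-fold lower number from compound 3 to compound 4 (0.60 log units; beyond the scatter) with hydrogen in place of methoxy. Fluoro and methoxy remain within the scatter of each other, so here the read-out separates hydrogen from both groups, not those two groups from one another. Nothing at hand explains this step. On these data alone, whether an amine, a carboxylic acid or a longer chain at this carbon would group with hydrogen or with fluoro and methoxy stays open.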